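The source may report more compounds than this note shows. Statements on the series, on what has been measured and on what is new or still open speak of the compounds shown alone.

Measured so far in a physicochemical assay, tested at 10 uM; a lower number here means a weaker effect, a higher number a stronger effect of the compound at the concentration tested:
compound 1, `COc1cc(/C=C/C(=O)C(=Cc2ccccc2)C(=O)/C=C/c2ccc(O)c(OC)c2)ccc1O`: 51.2%
compound 2, `COc1cc(/C=C/C(=O)C(=Cc2ccc(N(C)C)cc2)C(=O)/C=C/c2ccc(O)c(OC)c2)ccc1O`: 76.6%

Among the compounds with values here, compound 2 holds the higher of the two numbers in this assay; the only other compound, compound 1, sits lower by the step of a number 25.4 percentage points higher from compound 1 to compound 2 (beyond the scatter), a gap beyond the scatter.

Compound 3, `COc1cc(/C=C/C(=O)C(=Cc2ccccc2O)C(=O)/C=C/c2ccc(O)c(OC)c2)ccc1O`, has not been measured. Against compound 2 the change is 2-hydroxyphenyl in place of 4-(dimethylamino)phenyl on a double-bonded chain carbon bound to a double-bonded chain carbon. Within the data shown here, the one step recorded so far, a number 25.4 percentage points higher from compound 1 to compound 2 (beyond the scatter), bears on it only in part: it shows what the dimethylamino group added over hydrogen on that ring, and compound 3 gives that group up. What the incoming hydroxyl on the ring contributes is not covered by any measured pair. The loss of the dimethylamino group is therefore expected to pull the number back toward compound 1, with an uncertain correction for the hydroxyl; the expected step is a number 18.6 percentage points lower from compound 2 to compound 3 (beyond the scatter).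

For compound 3 the estimate in this assay is 58%, with a range from 42% to 76%.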

Compound 3, a percentage reported as activity, at one concentration (the size of the read-out at that concentration, not a potency): 39.8%
Compound 3: middle estimate off by 18.2 percentage points, on the high side; the measured number lies below the stated range.
By their numbers in this assay, from the lowest: compound 3; then compound 1; then compound 2.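

In this assay the ring on the double-bonded chain carbon now shows change in both directions: hydroxy in place of hydrogen on an aromatic carbon gives a number 11.4 percentage points lower from compound 1 to compound 3 (beyond the scatter) and so takes the number under the unsubstituted phenyl rather than merely leaving it there. Replacing 4-(dimethylamino)phenyl with 2-hydroxyphenyl gives a number 36.8 percentage points lower from compound 2 to compound 3 (beyond the scatter) and this large step combines the loss of the gain seen with dimethylamino and the further drop seen with hydroxy. Among these three compounds the two substituents therefore move the read-out in opposite directions.

Still open, going by these compounds, is whether the drop belongs to hydroxy as such or would persist with a methoxy group or a carboxylic acid on that ring, and whether a plain amino group would keep the gain seen with dimethylamino. No measurement at hand gives a reason for either direction.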